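This account rests on a few compounds, and the source may have more. Where it says the series, first, only, none or still open, it means among the compounds named here.

Compound 1, `Cn1c(-c2ccc(NC(=O)CSc3nc4ccccc4o3)cc2)nc(-c2ccccc2)c1-c1ccccc1`, gives 81.5% in a functional assay on HT-29 cells (Homo sapiens) for cytotoxicity, read by MTT assay, with a stated time of 24 h, tested at 80 ug/mL; a lower number here means a weaker effect, a higher number a stronger effect of the compound at the concentration tested. Compound 2, `Cc1ccc2oc(SCC(=O)Nc3ccc(-c4nc(-c5ccccc5)c(-c5ccccc5)n4C)cc3)nc2c1`, carries methyl in place of hydrogen on an aromatic carbon and gives 69.8% in this assay, so that a number 11.7 percentage points lower from compound 1 to compound 2 (beyond the scatter). Compound 3, `Cn1c(-c2ccc(NC(=O)CN3CCN(Cc4ccccc4)CC3)cc2)nc(-c2ccccc2)c1-c1ccccc1`, gives 54.5% in this assay, the lowest of the three numbers; how its core differs from that of compound 1 is not broken down here. Compound 4, `Cc1ccc(CN2CCN(CC(=O)Nc3ccc(-c4nc(-c5ccccc5)c(-c5ccccc5)n4C)cc3)CC2)cc1`, is yet to be measured and differs from compound 3 by methyl in place of hydrogen on an aromatic carbon. This is the same kind of change as that from compound 1 to compound 2, not the same one: there the methyl sat on a ring that is part of a fused system, meta and para to a fused ring, here it sits on a six-membered ring of carbon only, para to a large group. Because of a number 11.7 percentage points lower from compound 1 to compound 2 (beyond the scatter), a step of a number 9.5 percentage points lower from compound 3 to compound 4 (within the scatter) is expected. For compound 4 the expected read-out in this assay is 45%, between 25% and 65%.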

Compound 4, a percentage reported as activity, at one concentration (the size of the read-out at that concentration, not a potency): 54.2%
Beside the measured number, compound 4's estimate is 9.2 percentage points below it, within the range that was stated.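

On the core of compound 3, the methyl in place of hydrogen gave a number 0.3 percentage points lower from compound 3 to compound 4 (within the scatter) in this assay, so the change from benzyl to 4-methylbenzyl left no readable effect there. Set beside the earlier step, the result shows no difference between the two cores that can be told from scatter: the same change on two cores in this assay, a number 11.7 percentage points lower (beyond the scatter) from compound 1 to compound 2 and a number 0.3 percentage points lower (within the scatter) from compound 3 to compound 4, 11.4 percentage points apart, within the scatter of two such steps This does not show that the change carries over with the same size, since each core offers a single pair, only the earlier step lies beyond the scatter, and the methyl sits on a different kind of ring in each pair.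

The compounds shown leave open how an ethyl, a methoxy or a chlorine in that place would read on either core. Each read-out also comes from one concentration, so it tells only of a stronger or weaker effect at that concentration.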